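This account rests on a few compounds, and the source may have more. Where it says the series, first, only, none or still open, it means among the compounds named here.

Compound 1 `COc1ccc2c(/C=C/C(=O)c3cc(OC)c(OC)c(SC)c3)c[nH]c2c1`: 115 nM
Compound 2 `COc1ccc2c(/C=C(\C)C(=O)c3cc(OC)c(OC)c([Se]C)c3)cn(C)c2c1`: 15 nM

In a functional assay on A549 cells (Homo sapiens) for antiproliferative activity, read by MTT assay, with a stated time of 48 h (on this read-out higher numbers stand for weaker inhibition and lower numbers for stronger inhibition), compound 1 has the higher number of the two, and its gap to compound 2 lies beyond the scatter. Compound 3 `COc1ccc2c(/C=C/C(=O)c3cc(OC)c(OC)c([N+](=O)[O-])c3)c[nH]c2c1` keeps the core of compound 1 but carries nitro in place of methylsulfanyl on an aromatic carbon, ortho to a methoxy group (nitro in place of methylsulfanyl on an aromatic carbon). Going by the values given here, no measured pair shows this change, so the expectation is a judgement. An estimated 4.3-fold higher number from compound 1 to compound 3 (0.64 log units; beyond the scatter) is expected, towards weaker inhibition and beyond the scatter. The expected value for compound 3 is 500 nM, within an estimated range of 150 nM to 2500 nM.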

Compound 3, half-maximal inhibitory concentration: 331 nM
The estimate for compound 3 lay 1.5-fold (0.18 log units) above the measured number, within the range that was stated.
By their numbers in this assay, from the lowest: compound 2; then compound 1; then compound 3.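

In this assay, nitro in place of methylsulfanyl on the aromatic carbon ortho to a methoxy group gives a 2.9-fold higher number from compound 1 to compound 3 (0.46 log units; beyond the scatter). This is a modest step towards weaker inhibition, beyond the scatter, and it shows that the number at this position depends on the group it carries, while compound 3 stays in the same broad range as compound 1. No evidence at hand accounts for this step. As far as these compounds go, whether an amine, a carboxylic acid or a longer chain at this position would give a lower or a higher number remains open.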